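A few compounds are considered here, and "the series" means these few. Any claim that something is new, unique, unknown or untested is made for them only; others in the source may bear on it.

Measured in a functional assay on MDA-MB-231 cells (Homo sapiens) for antiproliferative activity, read by sulforhodamine B assay, with a stated time of 48 h; a higher number here means a weaker inhibitor of growth, a lower number a stronger inhibitor of growth:
- compound 1 `CCCCCCc1cn(CCCN2C(=O)COc3ccccc32)nn1`: 1100 nM
- compound 2 `O=C1COc2ccccc2N1CCCn1cc(-c2ccccn2)nn1`: 4800 nM
- compound 3 `O=C1COc2ccccc2N1CCCn1cc(CO)nn1`: 5700 nM

Compound 3 cannot be told apart from its nearest neighbour, as the gap is within the scatter: a 1.2-fold higher number from compound 2 to compound 3 (0.07 log units; within the scatter). Its distance from the hexyl compound is real: a 5.2-fold higher number from compound 1 to compound 3 (0.71 log units; beyond the scatter).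

The next compound, compound 4 `O=C1COc2ccccc2N1CCCn1cc(C2(O)CCCCC2)nn1`, has 1-hydroxycyclohexyl in place of hydroxymethyl on an aromatic carbon of the five-membered aromatic ring with 3 nitrogen: 1-hydroxycyclohexyl in place of hydroxymethyl on an aromatic carbon.

Among the measured compounds shown here, no measured compound carries this group, so the guidance is indirect. Compound 4 keeps the hydroxy group of compound 3 but gains a six-membered non-aromatic ring of carbon only, which brings it partway towards the hexyl group of compound 1. The most relevant step is therefore a 5.2-fold higher number from compound 1 to compound 3 (0.71 log units; beyond the scatter), a modest one. The other step away from hexyl is similar in size: a 4.4-fold higher number from compound 1 to compound 2 (0.64 log units; beyond the scatter). Together they suggest that added carbon may win back part of that distance, though not all of it, as the hydroxy group remains.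

A modest move towards a lower number is therefore expected, estimated as a 2.2-fold lower number from compound 3 to compound 4 (0.34 log units; beyond the scatter). For compound 4 the expected value is 2600 nM, with an estimated range of 1000 nM to 6500 nM.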

Compound 4, concentration for 50% growth inhibition: 1200 nM
Compound 4: middle estimate off by 2.2-fold (0.34 log units), on the high side; measured number inside the range.
By their numbers in this assay, from the lowest: compounds 1 and 4 (each within the scatter of the next); then compounds 2 and 3 (each within the scatter of the next).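

In this assay, keeping the hydroxy group while adding a six-membered non-aromatic ring of carbon only gives a 4.8-fold lower number from compound 3 to compound 4 (0.68 log units; beyond the scatter), so at this aromatic carbon of the five-membered aromatic ring with 3 nitrogen, a hydroxy group does not by itself hold the number up. The change also makes the hydroxy compound indistinguishable from the hexyl compound, with a 1.1-fold higher number from compound 1 to compound 4 (0.04 log units; within the scatter), and clearly separates it from the pyridin-2-yl compound, with a 4.0-fold lower number from compound 2 to compound 4 (0.60 log units; beyond the scatter), so among these four compounds a group rich in saturated carbon goes with the lower numbers, while compound 3, with its smaller hydroxymethyl group, and compound 2, with its aromatic ring, share the higher ones. Nothing available explains why these groups differ in this way.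

The compounds shown leave open whether the hydroxy group of compound 4 matters at all, which a plain cyclohexyl group or an amine in place of the hydroxy group would test. They also leave open how much carbon is needed at this place, which a butyl chain or a cyclopentyl ring could begin to answer.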